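Methyl next to the ring sulfur: compound 3 to compound 4

A few compounds are considered here, and "the series" means these few. Any claim that something is new, unique, unknown or untested is made for them only; others in the source may bear on it.

Compound 3 `Cc1c(CC(=O)O)c2ccsc2n1Cc1ccc(S(C)(=O)=O)cc1Cl` gives 10 nM in an assay on HEK293 cells for displacement of a labelled ligand from prostaglandin D2 receptor 2 (Homo sapiens) (on this read-out higher numbers stand for weaker inhibition and lower numbers for stronger inhibition), the lowest of the three numbers at hand. Compound 1 `Cc1c(CC(=O)O)c2ccsc2n1S(=O)(=O)c1ccc(S(C)(=O)=O)cc1` gives 90 nM in this assay, and compound 2 `Cc1c(CC(=O)O)c2ccsc2n1S(=O)(=O)c1ccc(S(=O)(=O)N2CCOCC2)cc1` gives 230 nM in this assay; both stand above compound 3 by gaps beyond the scatter. For the measured compounds named here, the only single-point step measured so far, a 2.6-fold higher number from compound 1 to compound 2 (0.41 log units; beyond the scatter), concerns the substituent on the sulfonyl sulfur, a different part of the molecule from the shared core.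

Compound 4 `Cc1cc2c(CC(=O)O)c(C)n(Cc3ccc(S(C)(=O)=O)cc3Cl)c2s1` differs from compound 3 by methyl in place of hydrogen on an aromatic carbon, on the aromatic carbon of the five-membered aromatic ring with 1 sulfur, next to the ring sulfur. Going by the values given here, no measured pair alters this ring, so the step from compound 1 to compound 2 gives no guidance here, and the data hold nothing else on the shared core. The expected step is therefore no change at the digits printed from compound 3 to compound 4 (within the scatter), within the scatter, with wide uncertainty. Compound 4 is estimated at 10 nM in this assay, with a range from 3 nM to 35 nM.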

Compound 4, half-maximal inhibitory concentration: 330 nM
Compound 4: the middle estimate sits 33-fold (1.52 log units) below what was measured; measured number above the stated range.
By their numbers in this assay, from the lowest: compound 3; then compound 1; then compounds 2 and 4 (each within the scatter of the next).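

Hydrogen on this aromatic carbon, next to the ring sulfur, proves to be a sensitive point in this assay: methyl in place of hydrogen, one added carbon, gives a large weakening (a 33-fold higher number from compound 3 to compound 4 (1.52 log units; beyond the scatter)). For the compounds shown here, the earlier step (a 2.6-fold higher number from compound 1 to compound 2 (0.41 log units; beyond the scatter)) lay at the sulfonyl sulfur, so this is the first measured sign that a change on the shared core can outweigh the gain held by compound 3. Nothing at hand accounts for this weakening.

From the compounds shown here alone, whether the loss is peculiar to methyl remains open: a fluorine atom, a methoxy group or a longer chain such as ethyl on this same carbon could follow it or depart from it. Also open, going by these compounds, is whether methyl at this place gives a step of like size on compound 1, with its sulfonyl link.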